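This account rests on a few compounds, and the source may have more. Where it says the series, first, only, none or still open, it means among the compounds named here.

Working notes on the series.

Three compounds have been taken through a functional assay on MT4 cells (Homo sapiens) for cytotoxicity, read by MTT assay; a lower number here means that less compound is tolerated, a higher number that more compound is tolerated. Compound 1 `Cc1c(O)nc(S(=O)(=O)Cc2ccc(Br)cc2)nc1Cc1c(Cl)cccc1Cl` gives > 50000 nM, which is a limit of the assay and not a number. Compound 2 `Cc1c(Cc2c(F)cccc2F)nc(SCc2ccc([N+](=O)[O-])cc2)[nH]c1=O` gives > 62000 nM, likewise a limit of the assay. Compound 3 `CCOc1ccc(CSc2nc(O)c(C)c(Cc3c(Cl)cccc3Cl)n2)cc1` gives > 58000 nM, again a limit and not a number. So compound 3 stands at a limit, and the two further values shown are limits as well: the limit of > 50000 nM in this assay, at which 1 of the 3 values shown sits, the limit of > 58000 nM in this assay, at which 1 of the 3 values shown sits, and the limit of > 62000 nM in this assay, at which 1 of the 3 values shown sits, leave no measured step within this group, only three readings at or past the top of the tested range.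

The next compound, compound 4 `Cc1c(O)nc(SCc2ccc([N+](=O)[O-])cc2)nc1Cc1c(Cl)cccc1Cl`, differs from compound 3 in one place: nitro in place of ethoxy on an aromatic carbon. Within the data shown here, no measured step shows what this change does in this assay, but compound 2 already carries the 4-nitrophenyl group and sits at a limit. From compound 3 to compound 4 no step beyond the scatter is expected, the estimated move being a step that the limit leaves unreadable from compound 3 to compound 4. Compound 4 is therefore expected to give about 60000 nM in this assay, with a range from 30000 nM to 110000 nM, most likely reported once more as a limit rather than a number.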

Compound 4, half-maximal cytotoxic concentration: > 58000 nM
Compound 4 gave a limit, no number; the forecaster's own chance of this, stated with the estimate: 85%; the middle value is on the limit's open side.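

Compound 3 and compound 4 both stand at a limit in this assay, so nitro in place of ethoxy gives no readable step from compound 3 to compound 4. The compounds shown leave open at what concentration any of the four would show cytotoxicity, and whether this change makes any difference there.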